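Does turning the double bond change compound 4?

This account rests on a few compounds, and the source may have more. Where it says the series, first, only, none or still open, it means among the compounds named here.

In a functional assay on HT-1080 cells (Homo sapiens) for inhibition, read by sulforhodamine B assay, with a stated time of 48 h (on this read-out lower numbers stand for stronger inhibition and higher numbers for weaker inhibition), compound 1 `CCNC(=O)Nc1ccc(/C=C\c2cc(OC)c(OC)c(OC)c2)cc1` gives 29000 nM and compound 2 `CCNC(=O)Nc1ccc(/C=C/c2cc(OC)c(OC)c(OC)c2)cc1` gives 16000 nM. Compound 3 `COc1cc(/C=C/c2ccc(N3CCNC3=O)cc2)cc(OC)c1OC` has the lowest number of the three at 400 nM, and the large 40-fold lower number from compound 2 to compound 3 (1.60 log units; beyond the scatter) comes with 2-oxoimidazolidin-1-yl in place of (ethylcarbamoyl)amino on an aromatic carbon. Compound 4 `COc1cc(/C=C\c2ccc(N3CCNC3=O)cc2)cc(OC)c1OC` alters only the double bond: the two compounds have the same atoms and bonds and differ only in configuration as drawn: 1 of 1 stereo elements differ; a double bond is drawn E in compound 3 and Z in compound 4. For the measured compounds named here, the one measured step of this kind, a 1.8-fold lower number from compound 1 to compound 2 (0.26 log units; within the scatter), ran from Z to E and stayed within the scatter. The same change has not been measured with the 2-oxoimidazolidin-1-yl group, so this is thin support. The expected result is a 1.3-fold higher number from compound 3 to compound 4 (0.10 log units; within the scatter), with no change beyond the scatter in this assay. For compound 4 the estimated value is 500 nM, with an expected range of 120 nM to 2500 nM.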

Compound 4, half-maximal inhibitory concentration: 2.3 nM
For compound 4 the middle estimate is 220-fold (2.34 log units) above the measured one; measured number outside the range, below it.
By their numbers in this assay, from the lowest: compound 4; then compound 3; then compounds 2 and 1 (each within the scatter of the next).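

In this assay, the double bond matters greatly when 2-oxoimidazolidin-1-yl is present: turning it from E to Z gives a 170-fold lower number from compound 3 to compound 4 (2.24 log units; beyond the scatter), whereas the same turn between compound 1 and compound 2 stayed within the scatter. With the double bond Z, the swap of (ethylcarbamoyl)amino for 2-oxoimidazolidin-1-yl gives a 13000-fold lower number from compound 1 to compound 4 (4.10 log units; beyond the scatter). The two changes therefore do not act independently in these four compounds, since the gain from the swap depends on the double bond: the same change on two cores in this assay, a 40-fold lower number (1.60 log units; beyond the scatter) from compound 2 to compound 3 and a 13000-fold lower number (4.10 log units; beyond the scatter) from compound 1 to compound 4, 320-fold (2.50 log units) apart, beyond the scatter of two such steps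

On these data alone, it remains open whether the Z form would show the same advantage with another group in this place, such as a simple amine or a carboxylic acid.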